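The source may report more compounds than this note shows. Statements on the series, on what has been measured and on what is new or still open speak of the compounds shown alone.

Three compounds have been measured in an assay on isolated protein for inhibition of Amine oxidase [flavin-containing] B (Homo sapiens), read by fluorescence and Amplex Red, with a stated time of 30 min, tested at 100 uM; a higher number here means a stronger effect of the compound at the concentration tested, a lower number a weaker effect:

compound 1, `CCCCNc1nnc(SCC(=O)N(Cc2cccc([N+](=O)[O-])c2)c2ccc(F)cc2)s1`, gives 34.3%
compound 2, `CCCNc1nnc(SCC(=O)N(Cc2cccc([N+](=O)[O-])c2)c2ccc(F)cc2)s1`, gives 26.8%
compound 3, `COCCNc1nnc(SCC(=O)N(Cc2cccc([N+](=O)[O-])c2)c2ccc(F)cc2)s1`, gives 25.7%

All three share one core and differ only in the saturated chain on the nitrogen on the aromatic ring. Among the compounds with values here, compound 3 sits close to the other two: a number 8.6 percentage points lower from compound 1 to compound 3 (within the scatter), and a number 1.1 percentage points lower from compound 2 to compound 3 (within the scatter), so none of the three numbers is separated from the others beyond the scatter, and no compound can be called the stronger or weaker one.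

Compound 4, `C=CCNc1nnc(SCC(=O)N(Cc2cccc([N+](=O)[O-])c2)c2ccc(F)cc2)s1`, is the next member of this set and has not yet been measured. It differs from compound 3 in one place: vinyl in place of methoxymethyl on a saturated chain carbon bound to a nitrogen on an aromatic ring.

Within the data shown here, the steps that bear on this change are the two that already alter the same chain, a number 8.6 percentage points lower from compound 1 to compound 3 (within the scatter) and a number 1.1 percentage points lower from compound 2 to compound 3 (within the scatter), along with a number 7.5 percentage points lower from compound 1 to compound 2 (within the scatter); each lies within the scatter. The change from the methoxymethyl to the vinyl is of the same kind, so no step beyond the scatter is expected in either direction: the expected step is a number 2.3 percentage points higher from compound 3 to compound 4 (within the scatter). Compound 4 is therefore estimated at 28%, in a range from 15% to 42%.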

Compound 4, a percentage reported as inhibition, at one concentration (the size of the read-out at that concentration, not a potency): 29.2%
Estimate against measurement, compound 4: 1.2 percentage points below; the range from low to high includes it.
By their numbers in this assay, from the lowest: compounds 3, 2, 4 and 1 (each within the scatter of the next).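

In this assay, the change from methoxymethyl to vinyl on a saturated chain carbon bound to a nitrogen on an aromatic ring gives a number 3.5 percentage points higher from compound 3 to compound 4 (within the scatter), so an allyl chain, with its double bond and without the oxygen, stays level with the 2-methoxyethyl chain. Set against the two saturated chains, the allyl chain gives a number 2.4 percentage points higher from compound 2 to compound 4 (within the scatter) and a number 5.1 percentage points lower from compound 1 to compound 4 (within the scatter), so the double bond separates compound 4 from none of the three earlier compounds. Nothing available bears on the reason for these readings.

The compounds shown leave open whether a terminal amine, a carboxylic acid, a phenyl ring or a much longer chain at this place would move the number beyond the scatter. Each compound is read at a single concentration, so the numbers show only the size of the effect at that concentration.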